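From 4-fluorophenyl to 4-ethoxyphenyl

The compounds below may be only part of what the source reports. "The series", "measured", "known", "first", "only" and "open" are said of these compounds alone.

In a functional assay on MCF7 cells (Homo sapiens) for cytotoxicity, read by WST assay, with a stated time of 72 h (on this read-out higher numbers stand for weaker inhibition and lower numbers for stronger inhibition), compound 1 `O=C1Nc2c(ccc(F)c2F)C1(c1ccccc1)c1ccc(O)cc1` gives 7.1 nM. In this assay compound 2 `O=C1Nc2c(ccc(F)c2F)C1(c1ccc(O)cc1)c1ccc(F)cc1` gives 2.6 nM, the lower of the two single numbers in the series. Among the measured compounds shown here, the one measured step, a 2.7-fold lower number from compound 1 to compound 2 (0.44 log units; beyond the scatter), is modest and comes with fluoro in place of hydrogen on an aromatic carbon. Compound 3 `COc1ccc(C2(c3ccc(O)cc3)C(=O)Nc3c2ccc(F)c3F)cc1` gives 2.1 nM; 6.3 nM; > 1000 nM (3 entries) in this assay. The last entry of compound 3 is a limit of the assay and not a number.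

Compound 4 `CCOc1ccc(C2(c3ccc(O)cc3)C(=O)Nc3c2ccc(F)c3F)cc1` follows from compound 2 with ethoxy in place of fluoro on an aromatic carbon, para to a large group (ethoxy in place of fluoro on an aromatic carbon). The measured step touches the same place, but it involves a much smaller substituent change and gives only a rough scale. The closest measured structure is compound 3 (the several entries of compound 3 in this assay, 2.1 nM; 6.3 nM; > 1000 nM (3 entries)), whose entries, one of them a limit, are widely spread. The expected step in this assay is small and toward a higher number, a 1.9-fold higher number from compound 2 to compound 4 (0.28 log units; within the scatter). For compound 4 the estimate is 5 nM, with an expected range from 1.5 nM to 40 nM.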

Compound 4, half-maximal inhibitory concentration: 11 nM
Beside the measured number, compound 4's estimate is 2.2-fold (0.34 log units) below it, within the range that was stated.
By their numbers in this assay, from the lowest: compound 2; then compounds 1 and 4 (each within the scatter of the next).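

At this position the 4-ethoxyphenyl group gives up the advantage of the 4-fluorophenyl group in this assay, a modest step but one that clears the scatter (a 4.2-fold higher number from compound 2 to compound 4 (0.63 log units; beyond the scatter)). Set against the unsubstituted phenyl, ethoxy shows no separation (a 1.5-fold higher number from compound 1 to compound 4 (0.19 log units; within the scatter)), so this position accepts the larger ethoxy group without a loss beyond the scatter relative to hydrogen, and only fluoro stands apart from compound 1. The steps to compound 3, the methoxy analogue, cannot be read, as its entries are widely spread and one of them is a limit and not a number: the several entries of compound 3 in this assay, 2.1 nM; 6.3 nM; > 1000 nM (3 entries)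

Open, as far as these compounds go, is whether a longer chain such as propoxy continues the direction seen with ethoxy. Also open, from the compounds shown here alone, is how an amine or a carboxylic acid at this position would compare with fluoro and ethoxy.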